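Bromine for fluorine on the benzyl arm

The source may hold more compounds than are shown below. What is called first, only, known or untested is meant among the compounds shown, and "the series" means these compounds.

Three compounds sharing one core were tested for cytotoxicity in a toxicity assay on NIH3T3 cells (Mus musculus) for cytotoxicity, read by resazurin assay; on this read-out lower numbers stand for an effect already at smaller amounts and higher numbers for an effect only at larger amounts of compound. Compound 1 `COC(=O)c1ccc(NCc2cncn2Cc2ccc(C#N)cc2)cc1-c1ccccc1` gives only a limit of the assay, > 10000 nM. Compound 2 `COC(=O)c1ccc(NCc2cncn2Cc2ccccc2C#N)cc1-c1ccccc1` gives 25000 nM. The step that the limit leaves unreadable from compound 1 to compound 2 cannot be sized because of the limit of > 10000 nM in this assay, at which 1 of the 3 values shown sits. For compound 3 `COC(=O)c1ccc(NCc2cncn2Cc2ccccc2F)cc1-c1ccccc1` the read-out is "not determined" (no result reported), so compound 3 stands on no number of its own among the values shown. Compound 4 `COC(=O)c1ccc(NCc2cncn2Cc2ccccc2Br)cc1-c1ccccc1` differs from compound 3 by bromo in place of fluoro on an aromatic carbon. No measured step bears on this change, and the single step shown is unreadable. Both numbers seen lie in the weakly cytotoxic range, so no step beyond the usual scatter is expected in this assay. Compound 4 is estimated at 25000 nM, expected between 8000 nM and 80000 nM.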

Compound 4, half-maximal effective concentration: 10000 nM
Beside the measured number, compound 4's estimate is 2.5-fold (0.40 log units) above it; the range from low to high includes it.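

In this assay the readable step is a 2.5-fold lower number from compound 2 to compound 4 (0.40 log units; beyond the scatter), so that bromo in place of cyano on this aromatic carbon lowers the number beyond the scatter, though only modestly. The other step is a number no higher from compound 1 to compound 4 (the limit leaves the size open), and it cannot be read: the limit of > 10000 nM in this assay, at which 1 of the 4 values shown sits.

From the compounds shown here alone, how bromo compares with the fluoro of compound 3 stays open, with no number on that side of the change. Also open, going by these compounds, is how an amine or a carboxylic acid on this aromatic carbon would read.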